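The source may report more compounds than this note shows. Statements on the series, on what has been measured and on what is new or still open speak of the compounds shown alone.

Of the compounds shown here, three built on one shared core have been measured in an assay on isolated protein for inhibition of ubiquitin carboxyl-terminal hydrolase 7 (Homo sapiens), with stated times of 30 min and 2 h; on this read-out lower numbers stand for stronger inhibition and higher numbers for weaker inhibition. Compound 1 `Cn1nc2c(=O)n(CC3(O)CCN(Cc4ccc(-c5ccco5)cc4Cl)CC3)cnc2c1-c1ccc(C2(N)CC2)cc1` gives 66.1 nM. Compound 2 `CC(=O)NCc1ccc(-c2c3ncn(CC4(O)CCN(Cc5ccc(-c6ccco6)cc5Cl)CC4)c(=O)c3nn2C)cc1` gives 46.1 nM in this assay. Compound 3 `Cn1nc2c(=O)n(CC3(O)CCN(Cc4ccc(-c5ccco5)cc4Cl)CC3)cnc2c1-c1ccc(C(N)=O)cc1` gives 80.8 nM in this assay, the highest of the three numbers; the steps that reach it are a 1.2-fold higher number from compound 1 to compound 3 (0.09 log units; within the scatter) and a 1.8-fold higher number from compound 2 to compound 3 (0.24 log units; within the scatter), both within the scatter, so no order among the three can be read from these values. The account now turns to compound 4 `CC(C)NCc1ccc(-c2c3ncn(CC4(O)CCN(Cc5ccc(-c6ccco6)cc5Cl)CC4)c(=O)c3nn2C)cc1`, which differs from compound 3 in one place: (isopropylamino)methyl in place of carbamoyl on an aromatic carbon. The measured step that bears on this exchange is the one at the same aromatic carbon from compound 2 to compound 3, which was within the scatter, as was the step of a 1.4-fold lower number from compound 1 to compound 2 (0.16 log units; within the scatter). Nothing among the three measured compounds points to a large movement, so the expected step from compound 3 to compound 4 is a 1.5-fold lower number from compound 3 to compound 4 (0.17 log units; within the scatter), a drift toward lower numbers that may well stay inside the scatter. Compound 4 is therefore estimated at 55 nM, with a range from 25 nM to 130 nM.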

Compound 4, half-maximal inhibitory concentration: 29.1 nM
For compound 4 the middle estimate is 1.9-fold (0.28 log units) above the measured one, within the range that was stated.
By their numbers in this assay, from the lowest: compounds 4, 2, 1 and 3 (each within the scatter of the next, the first and the last beyond it).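

Among the compounds shown here, at this aromatic carbon, para to a large group, every earlier exchange stayed within the scatter, whereas (isopropylamino)methyl gives the first steps beyond it in this assay: a 2.8-fold lower number from compound 3 to compound 4 (0.44 log units; beyond the scatter) and a 2.3-fold lower number from compound 1 to compound 4 (0.36 log units; beyond the scatter), both modest. Isopropyl in place of acetyl on the amine nitrogen does not separate the pair in the same way, with a 1.6-fold lower number from compound 2 to compound 4 (0.20 log units; within the scatter), so compound 4 stands apart from compound 3 and compound 1 but not from compound 2. Nothing measured here accounts for these differences.

The compounds shown leave open how a plain aminomethyl group, or a cyclopentyl or tert-butyl group on the same amine nitrogen, would read in this assay. They also leave open how a carboxylic acid on this aromatic carbon would read.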